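Swapping the aryl halide on the core of compound 1

A few compounds are considered here, and "the series" means these few. Any claim that something is new, unique, unknown or untested is made for them only; others in the source may bear on it.

Measured so far:
- compound 1 `O=C1C(=Cc2ccc(Br)cc2)C(=O)N(c2ccc(Cl)cc2)N1c1ccc(Cl)cc1`: 30400 nM
- compound 2 `COc1cc(C=C2C(=O)N(c3ccc(Cl)cc3)N(c3ccc(Cl)cc3)C2=O)cc(OC)c1OC`: 16200 nM
- compound 3 `O=C1C(=Cc2cccc(Cl)c2)C(=O)N(c2ccc(Cl)cc2)N1c1ccc(Cl)cc1`: 18300 nM

In a functional assay on MCF7 cells (Homo sapiens) for cytotoxicity, read by MTT assay, with a stated time of 72 h (on this read-out lower numbers stand for stronger inhibition and higher numbers for weaker inhibition), compound 1 stands at the highest of the three numbers, yet its gaps to compound 3 and to compound 2 both fall within the scatter, so no ranking among the three can be drawn. Compound 4 `O=C1C(=Cc2ccc(Cl)cc2Cl)C(=O)N(c2ccc(Cl)cc2)N1c1ccc(Cl)cc1` is made from compound 1 by a change at the same position that separates compound 1 from compound 3: 2,4-dichlorophenyl in place of 4-bromophenyl on a double-bonded chain carbon bound to a double-bonded ring carbon. Among the compounds with values here, the one related step, a 1.7-fold lower number from compound 1 to compound 3 (0.22 log units; within the scatter), stayed within the scatter. A comparable outcome, no shift beyond the scatter, is therefore expected here. The step that this estimate means is a 1.4-fold lower number from compound 1 to compound 4 (0.14 log units; within the scatter). For compound 4 a value of about 22000 nM is expected, with a likely range from 8000 nM to 60000 nM.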

Compound 4, half-maximal inhibitory concentration: > 128000 nM
Compound 4 ended at the assay's limit; the forecaster's own chance of this, stated with the estimate: 10%; middle value at least 5.8-fold (0.76 log units) from the limit.
By their numbers in this assay, from the lowest: compounds 2, 3 and 1 (each within the scatter of the next). At a limit, above all of these: compound 4.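

In this assay, the group on a double-bonded chain carbon bound to a double-bonded ring carbon turns out to matter: 2,4-dichlorophenyl gives an at least 4.2-fold higher number from compound 1 to compound 4 (0.62 log units; beyond the scatter) and an at least 6.9-fold higher number from compound 3 to compound 4 (0.84 log units; beyond the scatter), whereas the earlier swap gave only a 1.7-fold lower number from compound 1 to compound 3 (0.22 log units; within the scatter). So inhibition at this position can weaken clearly, not just shift within the noise. Compound 4 stands at a limit of the read-out, not at a number, so these steps have no upper size: the limit of > 128000 nM in this assay, at which 1 of the 4 values shown sits.

From the compounds shown here alone, it remains open whether either chlorine of 2,4-dichlorophenyl alone would bring the same loss. Going by these compounds, how an amine or a carboxylic acid on this phenyl ring would behave also remains open.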